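Benzoyl in Place of Bromofuranoyl on a Shared Core

The source may hold more compounds than are shown below. What is called first, only, known or untested is meant among the compounds shown, and "the series" means these compounds.

Among the measured compounds shown here, compound 1 `COc1cc2nc(N3CCN(C(=O)c4ccc(Br)o4)[C@H]4CCCC[C@H]43)nc(N)c2cc1OC` is one of three compounds measured in an assay on CHO cells for displacement of a labelled ligand from Alpha-1D adrenergic receptor (Homo sapiens) (on this read-out higher numbers stand for weaker inhibition and lower numbers for stronger inhibition), where compound 1 gives 1.55 nM. Compound 2 `COc1cc2nc(N3CCN(C(=O)c4cccs4)[C@H]4CCCC[C@H]43)nc(N)c2cc1OC` gives 2.34 nM and compound 3 `COc1cc2nc(N3CCN(C(=O)c4ccc[nH]4)[C@H]4CCCC[C@H]43)nc(N)c2cc1OC` gives 1.51 nM. On these numbers compound 1 holds the second highest value, nearest to compound 3 and furthest from compound 2, though all three lie within the scatter of one another. Compound 4 `COc1cc2nc(N3CCN(C(=O)c4ccccc4)[C@H]4CCCC[C@H]43)nc(N)c2cc1OC` differs from compound 1 by phenyl in place of 5-bromofuran-2-yl on a carbonyl carbon. For the measured compounds named here, the steps that bear on this exchange of the aromatic ring on the carbonyl carbon are a 1.5-fold higher number from compound 1 to compound 2 (0.18 log units; within the scatter) and a 1.0-fold lower number from compound 1 to compound 3 (0.01 log units; within the scatter), neither of which left the scatter. Compound 4 is therefore expected to show no step beyond the scatter in this assay, namely a 1.3-fold higher number from compound 1 to compound 4 (0.11 log units; within the scatter). In this assay compound 4 is estimated at 2 nM, with a range from 0.8 nM to 5 nM.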

Compound 4, inhibition constant: 3.24 nM
Compound 4: the middle estimate sits 1.6-fold (0.21 log units) below what was measured; the range from low to high includes it.
By their numbers in this assay, from the lowest: compounds 3, 1, 2 and 4 (each within the scatter of the next, the first and the last beyond it).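

In this assay this position on the carbonyl carbon now shows steps beyond the scatter, though modest ones. Phenyl is the entering group in both of them, a 2.1-fold higher number from compound 1 to compound 4 (0.32 log units; beyond the scatter) and a 2.1-fold higher number from compound 3 to compound 4 (0.33 log units; beyond the scatter) alike. The change does not separate phenyl from every five-membered ring, since a 1.4-fold higher number from compound 2 to compound 4 (0.14 log units; within the scatter) stays within the scatter. No evidence is at hand that explains these steps. The compounds shown leave open whether ring size or the hetero atom governs the difference. They also leave open how an amine or a carboxylic acid on the phenyl ring would read.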